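Swapping thiophen-2-yl for pyridin-3-yl: an expected read-out

The source may hold more compounds than are shown below. What is called first, only, known or untested is meant among the compounds shown, and "the series" means these compounds.

Compound 1 `C/C(=N/Nc1nc(-c2ccc(F)cc2F)cs1)c1ccco1` and compound 2 `C/C(=N/Nc1nc(-c2ccc(F)cc2F)cs1)c1cccs1` share a core and differ only in the ring on a carbon with a double bond to nitrogen. In an in vitro assay on BTI-TN-5B1-4 cells for inhibition of Amine oxidase [flavin-containing] A (Homo sapiens), read by Amplex Red, with a stated time of 15 min, tested at 100 uM (on this read-out lower numbers stand for less inhibition and higher numbers for more inhibition at the one concentration tested (going by the name of the read-out)), compound 1 gives 40%, and compound 2 gives 40%; the step of no change at the digits printed from compound 1 to compound 2 (within the scatter) is flat within the scatter. Compound 2 therefore stands level with compound 1 on the numbers at hand, with no order between them. Compound 3 `C/C(=N/Nc1nc(-c2ccc(F)cc2F)cs1)c1cccnc1` carries the change (pyridin-3-yl in place of thiophen-2-yl on a carbon with a double bond to nitrogen). For the measured compounds named here, the only measured step, no change at the digits printed from compound 1 to compound 2 (within the scatter), exchanged one five-membered aromatic ring for another and showed no movement; no measured step exchanges a five-membered ring for a six-membered one, so the expectation rests on that single flat step alone. The expected step of no change at the digits printed from compound 2 to compound 3 (within the scatter) is accordingly one of no size beyond the scatter. For compound 3 the estimate in this assay is 40%, with a range from 20% to 60%.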

Compound 3, a percentage reported as inhibition, at one concentration (the size of the read-out at that concentration, not a potency): 40%
Compound 3: middle estimate and measured number agree at the digits printed; the range from low to high includes it.
By their numbers in this assay, from the lowest: compounds 1, 2 and 3 (each within the scatter of the next).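

At this place, on a carbon with a double bond to nitrogen, the exchange now extends beyond five-membered rings: in this assay the step to pyridin-3-yl, a six-membered aromatic ring with one ring nitrogen, is no change at the digits printed from compound 2 to compound 3 (within the scatter). Measured against the furan-2-yl compound, the same ring gives no change at the digits printed from compound 1 to compound 3 (within the scatter), so all three aromatic rings shown stand level at this place. No evidence on why the ring size and the hetero atom leave this read-out flat is available here.

From the compounds shown here alone, whether a group other than an aromatic ring, such as an amine, a carboxylic acid or a longer chain, would leave the read-out level at this place stays open. The compounds shown also keep the shared core fixed, so they leave open what a change elsewhere in it would do.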